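The source may hold more compounds than are shown below. What is called first, only, known or untested is meant among the compounds shown, and "the series" means these compounds.

Compound 1 `Cc1ccc(NC(=O)Cn2cc(COc3ccc4c(c3)CCC4)nn2)cc1`, compound 2 `Cc1ccc(-n2cc(COc3ccc4c(c3)CCC4)nn2)cc1` and compound 3 `Cc1ccc([N+](=O)[O-])cc1-n1cc(COc2ccc3c(c2)CCC3)nn1` share a common core, and compound 4 `COc1ccc(-n2cc(COc3ccc4c(c3)CCC4)nn2)cc1` joins them as the one still to be measured. In an ADME assay on HEK293 cells (Homo sapiens) for inhibition, read by MTT assay, with a stated time of 48 h, tested at 25 uM (on this read-out lower numbers stand for less inhibition and higher numbers for more inhibition at the one concentration tested (going by the name of the read-out)), compound 3 gives 26.5%. In this assay compound 1 gives "not determined" (no result reported) and compound 2 gives "not determined" (no result reported), so compound 2 stands without a number of its own, and the only figure in this small series belongs to compound 3. The change from compound 2 to compound 4 is methoxy in place of methyl on an aromatic carbon. Going by the values given here, no measured pair showing such a change exists here, so the data give no direction for it; the account therefore expects a step in this assay no larger than the usual scatter, in no firm direction. Compound 4 is expected to give 22% in this assay, with a range from 5% to 42%. That expectation rests on compound 3, which gives 26.5% in this assay, as the nearest measured point.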

Compound 4, a percentage reported as inhibition, at one concentration (the size of the read-out at that concentration, not a potency): 21.1%
Estimate against measurement, compound 4: 0.9 percentage points above; low and high end bracket the measured number.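

Compound 4 gives 21.1% in this assay, but compound 2 stands there without a number, so no step can be read between compound 2 and compound 4. The compounds shown leave open how 4-methylphenyl and 4-methoxyphenyl compare, and no further data bear on this result.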